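Swapping chloro for bromo on the anilide ring

A few compounds are considered here, and "the series" means these few. Any claim that something is new, unique, unknown or untested is made for them only; others in the source may bear on it.

Of the compounds shown here, three sharing one core have been measured in a functional assay on PC-3 cells (Homo sapiens) for inhibition, read by MTT assay, with a stated time of 72 h; a higher number here means a weaker inhibitor, a lower number a stronger inhibitor. Compound 1 `O=C(CSc1nc(Nc2ccccc2)c2ccccc2n1)Nc1cccc(Cl)c1` gives 12600 nM, compound 2 `CCc1cccc(NC(=O)CSc2nc(Nc3ccccc3)c3ccccc3n2)c1` gives 11000 nM, and compound 3 `O=C(CSc1nc(Nc2ccccc2)c2ccccc2n1)Nc1ccc(Cl)cc1` gives 12900 nM. Compound 3 holds the highest of the three numbers, but the step of a 1.0-fold higher number from compound 1 to compound 3 (0.01 log units; within the scatter) and the step of a 1.2-fold higher number from compound 2 to compound 3 (0.07 log units; within the scatter) both stay within the scatter, so the three cannot be ordered against one another.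

Compound 4 `O=C(CSc1nc(Nc2ccccc2)c2ccccc2n1)Nc1ccc(Br)cc1` differs from compound 3 in one place: bromo in place of chloro on an aromatic carbon. Among the compounds with values here, the one measured step that also exchanges a group on that ring is a 1.1-fold lower number from compound 1 to compound 2 (0.06 log units; within the scatter), which did not move the number beyond the scatter, and no other measured pair touches the halogen itself. Nothing seen here therefore points to a shift either way, and the expected step of a 1.1-fold lower number from compound 3 to compound 4 (0.03 log units; within the scatter) is one of no change beyond the scatter. Compound 4 is accordingly estimated at 12000 nM in this assay, within a range of 6000 nM to 25000 nM.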

Compound 4, half-maximal inhibitory concentration: 8450 nM
Beside the measured number, compound 4's estimate is 1.4-fold (0.15 log units) above it; the measured number falls inside the stated range.
By their numbers in this assay, from the lowest: compounds 4, 2, 1 and 3 (each within the scatter of the next).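

In this assay the exchange of chloro for bromo gives a 1.5-fold lower number from compound 3 to compound 4 (0.18 log units; within the scatter) and so stays within the scatter: at this place, para to a large group, swapping one halogen for the other cannot be told from no change. The wider comparisons read alike, since a 1.3-fold lower number from compound 2 to compound 4 (0.11 log units; within the scatter) and a 1.5-fold lower number from compound 1 to compound 4 (0.17 log units; within the scatter) also stay within the scatter, so 4-bromophenyl on the amide-type nitrogen cannot be ordered against 3-ethylphenyl or 3-chlorophenyl. No measurement at hand offers an explanation for these numbers.

On these data alone, whether an amine or a carboxylic acid at this place would move the number beyond the scatter stays open. So does whether any change on this ring, rather than on the shared core, can do so.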